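This account rests on a few compounds, and the source may have more. Where it says the series, first, only, none or still open, it means among the compounds named here.

Compound 1 `Cc1ccc(C(=O)Nc2nc(Cl)c3cn(CC(C)(C)C)nc3n2)cc1` gives 5000 nM in an assay on CHO cells for displacement of a labelled ligand from adenosine receptor A3 (Homo sapiens), read by scintillation counting, with a stated time of 3 h; a lower number here means a stronger inhibitor, a higher number a weaker inhibitor. Compound 2 `CC(C)(C)Cn1cc2c(Cl)nc(NC(=O)c3ccccc3)nc2n1` gives 30300 nM. Compound 3 `CC(C)(C)Cn1cc2c(Cl)nc(NC(=O)c3ccc(F)cc3)nc2n1` gives 5900 nM.

Compound 1 holds the lowest number of the three: compound 3 is nearest, with a 1.2-fold higher number from compound 1 to compound 3 (0.07 log units; within the scatter), and compound 2 furthest, with a 6.1-fold higher number from compound 1 to compound 2 (0.78 log units; beyond the scatter). Compound 4 `CCOC(=O)c1nc(NC(=O)c2ccc(C)cc2)nc2nn(CC(C)(C)C)cc12` departs from compound 1 at the core: ethoxycarbonyl in place of chloro on an aromatic carbon. Within the data shown here, every measured step here changes the substituent on the benzamide ring, as in a 5.1-fold lower number from compound 2 to compound 3 (0.71 log units; beyond the scatter); none touches the core, so no measured step bears on this change. The expectation therefore rests on the change itself, and the expected step is a 1.3-fold lower number from compound 1 to compound 4 (0.10 log units; within the scatter), not beyond the scatter. Compound 4 is estimated at 4000 nM, with a range from 700 nM to 25000 nM.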

Compound 4, inhibition constant: 900 nM
Compound 4: middle estimate off by 4.4-fold (0.65 log units), on the high side; the measured number falls inside the stated range.
By their numbers in this assay, from the lowest: compound 4; then compounds 1 and 3 (each within the scatter of the next); then compound 2.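

With the rest of compound 1 held fixed, ethoxycarbonyl in place of chloro on this aromatic carbon gives a 5.6-fold lower number from compound 1 to compound 4 (0.74 log units; beyond the scatter) in this assay. This shows that the number responds to a change at the core as well as on the benzamide ring, and that the larger ester-bearing group comes with a lower number here. Nothing shown explains this step.

Going by these compounds, whether a carboxylic acid, an amide or an amine on this carbon would give a similar number remains open. So does whether ethoxycarbonyl would have a similar effect alongside the benzamide rings of compound 2 and compound 3.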